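The source may hold more compounds than are shown below. What is called first, only, known or untested is meant among the compounds shown, and "the series" means these compounds.

Measured in a functional assay on the whole organism (liver, strain NMRI) for inhibition, with Mus musculus as the target, with a stated time of 3 h, at a dose of 3 mg/kg by the oral route; a higher number here means more inhibition at the dose given (going by the name of the read-out), a lower number less inhibition:

compound 1 `O=[N+]([O-])c1cc(-c2nc(-c3ccc(Cl)c(Cl)c3)no2)cc(O)c1O`: 8.8%
compound 2 `O=[N+]([O-])c1cc(-c2nc(N3CCN(c4ccccn4)CC3)no2)cc(O)c1O`: 32.2%
compound 3 `CN1CCN(c2noc(-c3cc(O)c(O)c([N+](=O)[O-])c3)n2)CC1`: 56.8%

Compound 3 stands highest of the three, with a number 48 percentage points higher from compound 1 to compound 3 (beyond the scatter) and a number 24.6 percentage points higher from compound 2 to compound 3 (beyond the scatter) both beyond the scatter. Compound 4 `CC(=O)N1CCN(c2noc(-c3cc(O)c(O)c([N+](=O)[O-])c3)n2)CC1` is the next member; the change from compound 3 is acetyl in place of methyl on an amine nitrogen in a ring.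

Among the measured compounds shown here, only the step to compound 3 from compound 2 bears on this, since it also alters the group on the amine nitrogen in the ring: there the smaller methyl in place of pyridin-2-yl went with a modest rise. Replacing methyl by acetyl is the reverse direction in size, so a modest fall in this assay, or no change beyond the scatter, is expected for compound 4, the expected step being a number 14.8 percentage points lower from compound 3 to compound 4 (beyond the scatter). The estimate for compound 4 is 42%, in the range 18% to 66%.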

Compound 4, a percentage reported as inhibition, in the whole organism at one dose (the size of the read-out at that dose, not a potency): 68.2%
Beside the measured number, compound 4's estimate is 26.2 percentage points below it; the measured number lies above the stated range.
By their numbers in this assay, from the lowest: compound 1; then compound 2; then compound 3; then compound 4.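

In this assay, a larger group on the amine nitrogen in the ring does not have to lower the number: acetyl in place of methyl gives a number 11.4 percentage points higher from compound 3 to compound 4 (beyond the scatter) and acetyl in place of pyridin-2-yl gives a number 36 percentage points higher from compound 2 to compound 4 (beyond the scatter). Among the three groups on this nitrogen, acetyl now ranks first, then methyl, then pyridin-2-yl. No measurement available here accounts for this order.

As far as these compounds go, whether a propanoyl group, a methanesulfonyl group or a carboxylic acid on this nitrogen would match acetyl remains open. So does whether the order among these compounds holds at other doses or times.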